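Aryl Swap on a Dihydrofolate Reductase Inhibitor Pair

A few compounds are considered here, and "the series" means these few. Any claim that something is new, unique, unknown or untested is made for them only; others in the source may bear on it.

Compound 1 `NC1=NC2(CCOCC2)N(OCCCOc2cccc(Cl)c2Cl)C(N)=N1`: 89.8%
Compound 2 `Cc1cc(C)cc(OCCCON2C(N)=NC(N)=NC23CCOCC3)c1`: 88.6%

In an assay on isolated protein for inhibition of Dihydrofolate reductase (Homo sapiens), read by spectrophotometry, using NADPH, with stated times of 5 s and 6 min, tested at 50 uM (on this read-out higher numbers stand for a stronger effect at the one concentration tested and lower numbers for a weaker effect), compound 1 gives 89.8% and compound 2 gives 88.6%. Compound 2 sits at the lower end of these two numbers, yet the gap a number 1.2 percentage points lower from compound 1 to compound 2 (within the scatter) is within the scatter. Compound 3 `NC1=NC2(CCOCC2)N(OCCCOc2ccccc2Br)C(N)=N1` differs from compound 2 by 2-bromophenyl in place of 3,5-dimethylphenyl on an oxygen on a saturated carbon. Going by the values given here, the only measured step that bears on this, a number 1.2 percentage points lower from compound 1 to compound 2 (within the scatter), also exchanged one aryl group on the same oxygen and stayed within the scatter, so the expected step of a number 0.4 percentage points higher from compound 2 to compound 3 (within the scatter) is none beyond the scatter. Compound 3 is estimated at 89%, within 80% to 96%.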

Compound 3, a percentage reported as inhibition, at one concentration (the size of the read-out at that concentration, not a potency): 85%
Compound 3: the middle estimate sits 4 percentage points above what was measured; low and high end bracket the measured number.
By their numbers in this assay, from the lowest: compounds 3, 2 and 1 (each within the scatter of the next).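

In this assay, the swap to 2-bromophenyl on an oxygen on a saturated carbon gives a number 3.6 percentage points lower from compound 2 to compound 3 (within the scatter) and a number 4.8 percentage points lower from compound 1 to compound 3 (within the scatter). A ring with a single bromine therefore reads the same as the 3,5-dimethylphenyl and 2,3-dichlorophenyl rings, so three differently substituted aryl groups now fit this place without a step beyond the scatter. No measurement at hand explains this sameness.

From the compounds shown here alone, whether a cyclohexyl group, a pyridine or a ring bearing a carboxylic acid would also hold the read-out stays open. These readings at a single concentration also leave any differences in potency among the three compounds open.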